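This account rests on a few compounds, and the source may have more. Where it says the series, first, only, none or still open, it means among the compounds named here.

Measured compounds:
- compound 1, `COc1cccc(-c2cc(COc3ccc4oc(=O)ccc4c3)on2)c1`: "not determined" (no result reported) in a functional assay on HL-60 cells (Homo sapiens) for cytotoxicity, read by MTT assay, with a stated time of 48 h; a higher number here means a weaker inhibitor, a lower number a stronger inhibitor
- compound 2, `O=c1ccc2cc(OCc3cn(-c4cccc(CO)c4)nn3)ccc2o1`: "not determined" (no result reported) in this assay
- compound 3, `CC(=O)Nc1ccc(-n2cc(COc3ccc4oc(=O)ccc4c3)nn2)cc1`: 40400 nM in this assay

Compound 2 stands without a number in this assay, and compound 1 is in the same position, so the only figure in the whole set belongs to compound 3, which gives 40400 nM in this assay and is therefore a weak inhibitor. Compound 4 `O=c1ccc2cc(OCc3cn(-c4ccccc4[N+](=O)[O-])nn3)ccc2o1` differs from compound 2 in one place: 2-nitrophenyl in place of 3-(hydroxymethyl)phenyl on an aromatic nitrogen. Within the data shown here, no step between two measured compounds is available, so the size of the change from compound 2 to compound 4 in this assay cannot be read from any measured pair, and whether the move to 2-nitrophenyl shifts the number beyond the scatter, and in which direction, remains open. Because compound 3 gives 40400 nM in this assay, the shared core carrying a phenyl substituent on the aromatic nitrogen of the five-membered aromatic ring with three nitrogens appears to be weak, and compound 4 is expected to fall in a similar weak range. Compound 4 is expected to give about 35000 nM in this assay, with a likely range from 9000 nM to 120000 nM.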

Compound 4, half-maximal inhibitory concentration: 44600 nM
The estimate for compound 4 lay 1.3-fold (0.11 log units) below the measured number; low and high end bracket the measured number.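

Among these compounds, compound 4 gives 44600 nM in this assay, but compound 2 has no single number there, and no step between them can be read. The compounds shown leave open whether 2-nitrophenyl in place of 3-(hydroxymethyl)phenyl shifts the number in this assay, and in which direction. No supporting finding bears on the result of compound 4.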